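Swapping the methallyl for a benzyl on the amine

This account rests on a few compounds, and the source may have more. Where it says the series, first, only, none or still open, it means among the compounds named here.

Measured compounds:
compound 1 `CCCCN(C)Cc1c(C(F)(F)F)nc2n(-c3c(C)cc(C)cc3C)c(Cl)cn12`: 310 nM
compound 2 `C=C(C)CN(CC)Cc1c(C(F)(F)F)nc2n(-c3c(C)cc(C)cc3C)c(Cl)cn12`: 67 nM
compound 3 `Cc1cc(C)c(-n2c(Cl)cn3c(CN(CCC(F)(F)F)Cc4cccc(F)c4)c(C(F)(F)F)nc23)c(C)c1`: 49 nM

All three were tested in an assay on cells for displacement of a labelled ligand from corticotropin-releasing factor receptor 1 (Homo sapiens), with a stated time of 100 min; a higher number here means a weaker inhibitor, a lower number a stronger inhibitor. Compound 2 gives the second highest of the three numbers: compound 3 lies within the scatter of it, while compound 1 gives a higher number, beyond the scatter. Compound 4 `CCN(Cc1ccccc1)Cc1c(C(F)(F)F)nc2n(-c3c(C)cc(C)cc3C)c(Cl)cn12` is not yet measured. Its change from compound 2 is phenyl in place of 1-methylethenyl on a saturated chain carbon bound to an amine nitrogen. For the measured compounds named here, only one measured step touches this amine, a 4.6-fold lower number from compound 1 to compound 2 (0.67 log units; beyond the scatter), and it alters both chains at once, so it is a weak guide. Compound 3 also carries a benzyl-type group on that nitrogen, and in this assay compound 3 gives 49 nM, close to compound 2. Compound 4 is therefore expected to move only a little, a 1.2-fold lower number from compound 2 to compound 4 (0.09 log units; within the scatter), with an estimated value of 55 nM in the range 20 nM to 150 nM.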

Compound 4, inhibition constant: 350 nM
The estimate for compound 4 lay 6.4-fold (0.80 log units) below the measured number; the whole stated range lies below it.
By their numbers in this assay, from the lowest: compounds 3 and 2 (each within the scatter of the next); then compounds 1 and 4 (each within the scatter of the next).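

Phenyl in place of 1-methylethenyl on this saturated chain carbon is not a neutral swap: it gives a 5.2-fold higher number from compound 2 to compound 4 (0.72 log units; beyond the scatter). With a 1.1-fold higher number from compound 1 to compound 4 (0.05 log units; within the scatter), benzyl(ethyl)amino and butyl(methyl)amino cannot be told apart here, so the benzyl group gives up the gain seen with the 2-methylprop-2-en-1-yl group. Nothing available explains this loss.

Compound 3 differs from compound 4 in more than one place, so what allows its benzyl-type group to coexist with its value remains unresolved. A cyclopropylmethyl or pyridylmethyl group on this amine could show whether the aromatic ring itself matters.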